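Aryl swap on the alkyne of the cyclohexyl amide

The source may hold more compounds than are shown below. What is called first, only, known or untested is meant among the compounds shown, and "the series" means these compounds.

Measured so far, in an assay on HEK293 cells for displacement of a labelled ligand from metabotropic glutamate receptor 5 (Homo sapiens), with a stated time of 2 h; on this read-out higher numbers stand for weaker inhibition and lower numbers for stronger inhibition:
compound 1 `Cc1ccccc1C#Cc1ccc2c(n1)CCN(C)C2=O` gives > 32000 nM, a limit of the assay.
compound 2 `CN1CCc2nc(C#Cc3cccc(Cl)c3)ccc2C1=O` gives 250 nM.
compound 3 `Cc1ccccc1C#Cc1ccc2c(n1)CCN(C1CCCCC1)C2=O` gives > 32000 nM, a limit of the assay.

Compound 3 therefore stands at a limit and not at a number; it is one of the two values at the limit of > 32000 nM in this assay, at which 2 of the 3 values shown sit. Compound 1 stands at the same limit, so the step that the two limits leave unreadable from compound 1 to compound 3, and the effect of cyclohexyl in place of methyl on the amide-type nitrogen in the ring cannot be read from these two.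

Compound 4 `O=C1c2ccc(C#Cc3cccc(Cl)c3)nc2CCN1C1CCCCC1` differs from compound 3 by 3-chlorophenyl in place of 2-methylphenyl on a triple-bonded carbon. The same exchange has been measured once on the methyl amide: an at least 120-fold lower number from compound 1 to compound 2 (2.10 log units; beyond the scatter). Going by the values given here, that is the only measured step bearing on the present one. Going by these compounds, whether the cyclohexyl substituent shifts the size of that step is unknown, since compound 3 and compound 1 both sit at the limit.

Expected from that single comparison: a large fall in the number, an at least 16-fold lower number from compound 3 to compound 4 (1.20 log units; beyond the scatter), with wide uncertainty because the starting point for compound 3 is only a limit, > 32000 nM. The estimate for compound 4 in this assay is 2000 nM, with a range from 200 nM to 30000 nM.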

Compound 4, inhibition constant: 12000 nM
Estimate against measurement, compound 4: 6.0-fold (0.78 log units) below; the range from low to high includes it.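

In this assay, the exchange of 2-methylphenyl for 3-chlorophenyl on the triple-bonded carbon also lowers the number on the cyclohexyl amide, an at least 2.6-fold lower number from compound 3 to compound 4 (0.42 log units; beyond the scatter), so its benefit is no longer confined to the methyl amide. Going by these compounds alone, with 3-chlorophenyl in place, the nitrogen substituent can be read for the first time, and cyclohexyl in place of methyl costs much of the binding seen on the methyl amide, a 48-fold higher number from compound 2 to compound 4 (1.68 log units; beyond the scatter), whereas the same change on the 2-methylphenyl compounds cannot be read. The aryl exchange now has two measurements, although the size of the second is only a bound: the same change on two cores in this assay, an at least 120-fold lower number (2.10 log units; beyond the scatter) from compound 1 to compound 2 and an at least 2.6-fold lower number (0.42 log units; beyond the scatter) from compound 3 to compound 4; the limit leaves it open whether they differ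

The compounds shown do not separate the effect of the chlorine from that of where the substituent sits on the phenyl ring, a question that 3-methylphenyl or 2-chlorophenyl on the same cores would address. They also leave open how the number changes between the methyl and cyclohexyl amides, for which ethyl, isopropyl or cyclopropyl on the nitrogen, with 3-chlorophenyl kept, would give intermediate points.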